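The source may hold more compounds than are shown below. What is called first, only, known or untested is meant among the compounds shown, and "the series" means these compounds.

Measured so far in a functional assay, with a stated time of 60 min, tested at 0.1 mM; on this read-out higher numbers stand for a stronger effect at the one concentration tested and lower numbers for a weaker effect:
compound 1, `NCCCCCCNC(=O)c1c(O)c2ccccc2n(-c2ccccc2)c1=O`: 17.5%
compound 2, `Cn1c(=O)c(C(=O)NCCCCCCNC(=O)CCCCC2CCSS2)c(O)c2ccccc21`: 13%

Both numbers are small. Compound 2 stands at the lower of the two, but the gap to compound 1 is within the usual scatter, so the two measurements do not separate the compounds. Compound 3, `O=C(CCCCC1CCSS1)NCCCCCCNC(=O)c1c(O)c2ccccc2n(-c2ccccc2)c1=O`, remains to be measured in this assay. Against compound 2 the change is phenyl in place of methyl on an aromatic nitrogen. Among the measured compounds shown here, no pair of measured compounds isolates this change: compound 1 carries the phenyl on the same aromatic nitrogen but differs from compound 2 in the rest of the chain as well, so its value and that of compound 2 show only that both are low. For compound 3 the expected step of a number 2 percentage points higher from compound 2 to compound 3 (within the scatter) is none beyond the scatter, in either direction. The estimate for compound 3 in this assay is 15%, with a range from 5% to 28%.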

Compound 3, a percentage reported as activity, at one concentration (the size of the read-out at that concentration, not a potency): 10.2%
For compound 3 the middle estimate is 4.8 percentage points above the measured one; the measured number falls inside the stated range.
By their numbers in this assay, from the lowest: compounds 3, 2 and 1 (each within the scatter of the next).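

In this assay, phenyl in place of methyl on the aromatic nitrogen can now be read directly as a single change: a number 2.8 percentage points lower from compound 2 to compound 3 (within the scatter), so the swap is not resolved from the scatter at this position. The group of 11 heavy atoms in place of a hydrogen atom on the amine nitrogen can also be read on its own: a number 7.3 percentage points lower from compound 1 to compound 3 (within the scatter), and this change is not resolved either. Nothing at hand bears on these results.

Still open, on these data alone, is whether a benzyl group on the aromatic nitrogen would move the read-out beyond the scatter. The same question stands for a shorter or longer chain carrying the group of 11 heavy atoms, and for a carboxylic acid in place of that group.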